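Adding a Nitro Group to Compound 2

A few compounds are considered here, and "the series" means these few. Any claim that something is new, unique, unknown or untested is made for them only; others in the source may bear on it.

In a functional assay on HO8910 cells (Homo sapiens) for inhibition, read by MTT assay, with a stated time of 24 h, tested at 0.1 ug/mL (on this read-out lower numbers stand for less inhibition of growth and higher numbers for more inhibition of growth at the one concentration tested), compound 1 (`O=C(CCCCC1CCSS1)Nc1ccc([N+](=O)[O-])c(C(F)(F)F)c1`) is reported as "not active" (no number reported), with no number given. Among the compounds with values here, compound 2 (`O=C(CCCCC(S)CCS)Nc1cccc(C(F)(F)F)c1`) gives 10.8%, the only number available, so it has no measured neighbour to be ranked against. Compound 3 (`O=C(CCCCC(S)CCS)Nc1ccc([N+](=O)[O-])c(C(F)(F)F)c1`) differs from compound 2 by nitro in place of hydrogen on an aromatic carbon. Within the data shown here, no measured step shows what this change does, so no shift beyond the scatter is expected in this assay, in either direction. The expected step is a number 0.2 percentage points higher from compound 2 to compound 3 (within the scatter). Compound 3 is estimated at 11%, within a range of 2% to 25%.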

Compound 3, percent growth inhibition at one concentration: 1.95%
Compound 3: the middle estimate sits 9.1 percentage points above what was measured, outside the stated range (below it).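

In this assay, nitro in place of hydrogen on the aromatic carbon ortho to a trifluoromethyl group and para to a large group gives a number 8.9 percentage points lower from compound 2 to compound 3 (within the scatter). Within the data shown here, this is the first measured step at this position, and it does not separate the two compounds on this read-out. No available evidence bears on this result.

The compounds shown leave open whether an amine or a carboxylic acid on the same carbon would give a step beyond the scatter. They also leave open how such a step would look at any other concentration.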